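This account rests on a few compounds, and the source may have more. Where it says the series, first, only, none or still open, it means among the compounds named here.

In a functional assay on SMMC-7721 cells (Homo sapiens) for cytotoxicity, read by MTT assay, with a stated time of 24 h (on this read-out higher numbers stand for weaker inhibition and lower numbers for stronger inhibition), compound 1 (`O=C1/C(=C/c2cccnc2)CN(S(=O)(=O)c2ccc([N+](=O)[O-])cc2)C/C1=C\c1ccccc1F`) gives > 20000 nM as a limit of the assay and not a number. Among the compounds with values here, compound 2 (`O=C1/C(=C/c2ccncc2)CN(S(=O)(=O)c2ccc([N+](=O)[O-])cc2)C/C1=C\c1ccccc1F`) gives 15800 nM as the only true number so far, so it cannot yet be ranked against a second measured value. Compound 3 (`CC(=O)Nc1ccc(S(=O)(=O)N2C/C(=C\c3ccncc3)C(=O)/C(=C/c3ccccc3F)C2)cc1`) carries acetamido in place of nitro on an aromatic carbon, para to a large group. Within the data shown here, the one measured step is an at least 1.2-fold lower number from compound 1 to compound 2 (0.10 log units; that floor lies within the scatter) and it swaps pyridin-3-yl for pyridin-4-yl, elsewhere in the molecule. Among the measured compounds shown here, it therefore says nothing direct about this change, and no measured step covers nitro or acetamido. Without such evidence, no shift beyond the scatter is expected in this assay, and neither direction is favoured. The expected step is a 1.1-fold lower number from compound 2 to compound 3 (0.05 log units; within the scatter) and it is estimated to stay within the scatter. For compound 3 the estimate is 14000 nM with an expected range from 5000 nM to 30000 nM in this read-out.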

Compound 3, half-maximal inhibitory concentration: 13400 nM
Estimate against measurement, compound 3: 1.0-fold (0.02 log units) above, within the range that was stated.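

In this assay, within the data shown here, the first measured change on this aromatic carbon, para to a large group, gives a 1.2-fold lower number from compound 2 to compound 3 (0.07 log units; within the scatter). The values for the 4-nitrophenyl and 4-acetamidophenyl compounds therefore cannot be told apart, although acetamido brings a hydrogen-bond donor that nitro does not have. Among these compounds, this is the first direct evidence at this position, and it shows that this particular exchange produces no difference beyond the scatter, which the earlier pyridine step could not show.

From the compounds shown here alone, whether an amine or a carboxylic acid on this same aromatic carbon would produce a step beyond the scatter remains open. The pyridine step also stays without a firm size, as compound 1 gives only a limit of the assay and not a number: the limit of > 20000 nM in this assay, at which 1 of the 3 values shown sits.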